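This account rests on a few compounds, and the source may have more. Where it says the series, first, only, none or still open, it means among the compounds named here.

Measured in a functional assay on P388 cells (Mus musculus) for cytotoxicity; a higher number here means a weaker inhibitor, a lower number a stronger inhibitor:
- Compound 1 `Cc1cc(-c2c(F)cc3c(=O)c(Cc4ccc[nH]4)cn(C4CC4)c3c2F)cc(C)n1`: 930 nM
- Compound 2 `Cc1cc(-c2c(F)cc3c(=O)c(Cc4cccc(O)c4O)cn(C4CC4)c3c2F)cc(C)n1`: 880 nM
- Compound 3 `Cc1cc(-c2c(F)cc3c(=O)c(Cc4ncc[nH]4)cn(C4CC4)c3c2F)cc(C)n1`: 1100 nM

Compound 3, at 1100 nM, cannot be told apart from the other two compounds in this assay. Its steps, a 1.2-fold higher number from compound 1 to compound 3 (0.07 log units; within the scatter) and a 1.3-fold higher number from compound 2 to compound 3 (0.10 log units; within the scatter), are no larger than the differences expected between repeated measurements.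

Compound 4 `Cc1cc(-c2c(F)cc3c(=O)c(Cc4c[nH]cn4)cn(C4CC4)c3c2F)cc(C)n1` has the same atoms as compound 3, joined differently: 1H-imidazol-4-yl in place of 1H-imidazol-2-yl on a saturated chain carbon bound to an aromatic carbon. In words, 1H-imidazol-4-yl stands in place of 1H-imidazol-2-yl on a saturated chain carbon bound to an aromatic carbon. Among the measured compounds shown here, no measured pair shows this exact change, so the closest evidence is the other swaps of the group at that place. Besides the two steps above, there is a 1.1-fold lower number from compound 1 to compound 2 (0.02 log units; within the scatter). Even the change to the quite different 2,3-dihydroxyphenyl group left the number within the scatter.

No step beyond the scatter is therefore expected, and the estimated step is a 1.1-fold lower number from compound 3 to compound 4 (0.04 log units; within the scatter). For compound 4 the estimated value is 1000 nM, with an expected range from 500 nM to 2000 nM.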

Compound 4, half-maximal inhibitory concentration: 390 nM
Compound 4: middle estimate off by 2.6-fold (0.41 log units), on the high side, and the stated range ends above it.
By their numbers in this assay, from the lowest: compound 4; then compounds 2, 1 and 3 (each within the scatter of the next).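

The earlier compounds shown here made this place on the saturated chain carbon look indifferent to the group it carries, yet in this assay the swap to 1H-imidazol-4-yl gives a 2.8-fold lower number from compound 3 to compound 4 (0.45 log units; beyond the scatter) even though the counts of atoms, donors and acceptors stay the same. So how the ring is joined can matter here, even when the ring's atoms do not change. The same group also stands apart from the two other groups, with a 2.3-fold lower number from compound 2 to compound 4 (0.35 log units; beyond the scatter) and a 2.4-fold lower number from compound 1 to compound 4 (0.38 log units; beyond the scatter), which makes compound 4 the most potent of the four in this assay.

Nothing measured here explains why the way the ring is joined should make this difference. Also open, from the compounds shown here alone, is whether the lower number survives a longer chain between the core and the 1H-imidazol-4-yl ring, or a swap of that ring for an amine or a carboxylic acid.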